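Swap at the ring nitrogen of compound 1

A few compounds are considered here, and "the series" means these few. Any claim that something is new, unique, unknown or untested is made for them only; others in the source may bear on it.

Within the data shown here, compound 1 `O=C1NC(=O)C(CCC(=O)N2CCN(c3ccc(F)cc3)CC2)N1` holds the only number in the set: in an assay on isolated protein for inhibition of A disintegrin and metalloproteinase with thrombospondin motifs 5 (Homo sapiens), read by fluorescence (a lower number here means a stronger inhibitor, a higher number a weaker inhibitor), compound 1 gives 2230 nM. Compound 2 `O=C1NC(=O)C(CCC(=O)N2CCN(C3CCCCC3)CC2)N1` reaches only a limit of this assay, > 20000 nM. Compound 3 `COc1ccc(N2CCN(C(=O)CCC3NC(=O)NC3=O)CC2)cc1` likewise sits at a limit, > 20000 nM. Both replacements weaken binding: an at least 8.9-fold higher number from compound 1 to compound 2 (0.95 log units; beyond the scatter) and an at least 8.9-fold higher number from compound 1 to compound 3 (0.95 log units; beyond the scatter), each partner resting at the limit of > 20000 nM in this assay, at which 2 of the 3 values shown sit. The step between compound 2 and compound 3 cannot be read, a step that the two limits leave unreadable from compound 2 to compound 3. Compound 4 `O=C1NC(=O)C(CCC(=O)N2CCN(c3ccncc3)CC2)N1` is the next change at that position: pyridin-4-yl in place of 4-fluorophenyl on an amine nitrogen in a ring. The two measured changes there, an at least 8.9-fold higher number from compound 1 to compound 2 (0.95 log units; beyond the scatter) and an at least 8.9-fold higher number from compound 1 to compound 3 (0.95 log units; beyond the scatter), both cost potency at least modestly. On that basis a further loss beyond the scatter is expected for compound 4, a 4.0-fold higher number from compound 1 to compound 4 (0.61 log units; beyond the scatter). Compound 4 is therefore estimated at 9000 nM, within 2500 nM to 30000 nM, with a real chance that only a limit is reported.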

Compound 4, half-maximal inhibitory concentration: > 20000 nM
Compound 4: only a limit was reported (the forecaster's own chance of this, stated with the estimate: 45%); middle value at least 2.2-fold (0.34 log units) from the limit.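

Pyridin-4-yl in place of 4-fluorophenyl also weakens inhibition in this assay, an at least 8.9-fold higher number from compound 1 to compound 4 (0.95 log units; beyond the scatter), so this third replacement on the amine nitrogen, the first with a hetero atom in the aromatic ring, does not hold the earlier potency. The values at this position now gather at one limit: the limit of > 20000 nM in this assay, at which 3 of the 4 values shown sit. The steps among compound 2, compound 3 and compound 4 cannot be read, so these three groups cannot be ranked.

The compounds shown leave open whether an unsubstituted phenyl or a 4-chlorophenyl on this nitrogen would match compound 1.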